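Amide nitrogen swap from compound 3 to compound 4

The compounds below may be only part of what the source reports. "The series", "measured", "known", "first", "only" and "open" are said of these compounds alone.

In a functional assay on MDA-MB-435 cells (Homo sapiens) for cytotoxicity, read by MTT assay, with a stated time of 72 h (on this read-out lower numbers stand for stronger inhibition and higher numbers for weaker inhibition), compound 3 (`C[C@H](NC(=O)c1nc(Br)c2cccnc2c1N[C@H]1CC[C@H](N)CC1)c1ccc(F)cc1`) gives > 10000 nM as a limit of the assay and not a number. Compound 1 (`N[C@H]1CC[C@H](Nc2c(C(=O)NCc3ccco3)nc(Br)c3cccnc23)CC1`) with its (furan-2-yl)methyl group gives > 10000 nM as a limit too. Compound 2 (`CN(C)c1ccc(CNC(=O)c2nc(Br)c3cccnc3c2N[C@H]2CC[C@H](N)CC2)cc1`) gives 4000 nM as a true number. Compound 3 thus stands with the limit of > 10000 nM in this assay, at which 2 of the 3 values shown sit, and has no readable position of its own.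

Compound 4 (`N[C@H]1CC[C@H](Nc2c(C(=O)NCc3ccccn3)nc(Br)c3cccnc23)CC1`) carries (pyridin-2-yl)methyl in place of 1-(4-fluorophenyl)ethyl on an amide-type nitrogen.

Changes measured on this same nitrogen give an at least 2.5-fold lower number from compound 1 to compound 2 (0.39 log units; beyond the scatter) and an at least 2.5-fold higher number from compound 2 to compound 3 (0.39 log units; beyond the scatter) and both depend on the number of compound 2. The remaining comparison shows a step that the two limits leave unreadable from compound 1 to compound 3 and adds no size. Only the 4-(dimethylamino)phenyl group of compound 2 has produced a readable value, and compound 4 does not carry it. The nearest measured neighbour of compound 4 is compound 1 at > 10000 nM as a limit, so no clear step beyond the scatter is expected in this assay. The expected change is an at least 1.1-fold lower number from compound 3 to compound 4 (0.04 log units; that floor lies within the scatter) and it may well stay unreadable. For compound 4 the estimate is 9000 nM with an expected range from 3500 nM to 20000 nM and a limit of the assay rather than a number is quite likely.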

Compound 4, half-maximal inhibitory concentration: 4000 nM
The estimate for compound 4 lay 2.3-fold (0.35 log units) above the measured number; the range from low to high includes it.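

On the amide-type nitrogen, (pyridin-2-yl)methyl gives a second readable value in this assay, with an at least 2.5-fold lower number from compound 3 to compound 4 (0.39 log units; beyond the scatter) and an at least 2.5-fold lower number from compound 1 to compound 4 (0.39 log units; beyond the scatter). For the compounds shown here, a readable value at this position therefore does not depend on the 4-(dimethylamino)phenyl group, which was the only group to give one among the earlier compounds; exchanging it for pyridin-2-yl gives no change at the digits printed from compound 2 to compound 4 (within the scatter). Compound 1 and compound 3 remain at a limit of the assay and not a number: the limit of > 10000 nM in this assay, at which 2 of the 4 values shown sit.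

Going by these compounds, the change from compound 3 to compound 4 removes the fluorine and the defined stereocentre and brings in the ring nitrogen all at once, so which of these carries the step stays open, and the true size of the steps from the two limits stays open too. Also open, on these data alone, is whether a morpholine, a carboxylic acid or a longer chain on the amide-type nitrogen would keep, improve or lose this level of cytotoxicity.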